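A few compounds are considered here, and "the series" means these few. Any claim that something is new, unique, unknown or untested is made for them only; others in the source may bear on it.

In a functional assay on MDA-MB-231 cells (Homo sapiens) for antiproliferative activity, read by spectrophotometry and resazurin assay, with a stated time of 72 h (on this read-out higher numbers stand for weaker inhibition and lower numbers for stronger inhibition), three compounds built on a shared core have been measured so far: compound 1 `CC(=O)CC1Oc2cc(O)ccc2C=C1c1ccc(O)cc1` gives 145000 nM, compound 2 `CC(C)CC(=O)CC1Oc2cc(O)ccc2C=C1c1ccc(O)cc1` gives 67000 nM and compound 3 `Cc1ccc(C(=O)CC2Oc3cc(O)ccc3C=C2c2ccc(O)cc2)cc1` gives 55000 nM. The numbers show a 1.2-fold lower number from compound 2 to compound 3 (0.09 log units; within the scatter), so these two compounds count as level. Both stand clear of compound 1, though not by much, as a 2.2-fold lower number from compound 1 to compound 2 (0.34 log units; beyond the scatter) shows.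

Compound 4 `COc1ccc(C(=O)CC2Oc3cc(O)ccc3C=C2c2ccc(O)cc2)cc1` keeps all of compound 3 except one group: methoxy in place of methyl on an aromatic carbon. This puts methoxy in place of methyl on an aromatic carbon, para to a large group, turning 4-methylphenyl into 4-methoxyphenyl.

For the measured compounds named here, no measured step makes this exact change, so the evidence is indirect. Replacing a whole group on the carbonyl carbon produced only a 2.6-fold lower number from compound 1 to compound 3 (0.42 log units; beyond the scatter), and the swap between isobutyl and 4-methylphenyl stayed within the scatter. A change confined to the outer end of the 4-methylphenyl group is therefore expected to produce no step beyond the scatter in this assay, in either direction.

The estimated step is no change at the digits printed from compound 3 to compound 4 (within the scatter). The expected value for compound 4 is 55000 nM, with an estimated range of 27000 nM to 110000 nM.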

Compound 4, half-maximal inhibitory concentration: 7600 nM
Estimate against measurement, compound 4: 7.2-fold (0.86 log units) above; the whole stated range lies above it.
By their numbers in this assay, from the lowest: compound 4; then compounds 3 and 2 (each within the scatter of the next); then compound 1.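

For the compounds shown here, the outer end of the 4-methylphenyl group matters more than the earlier compounds suggested. In this assay, exchanging only methyl for methoxy on that aromatic carbon gives a 7.2-fold lower number from compound 3 to compound 4 (0.86 log units; beyond the scatter) and so outdoes every replacement of a whole group on the carbonyl carbon among the first three compounds, even though isobutyl and 4-methylphenyl had stood level there. Going by these compounds alone, the 4-methoxyphenyl group now stands clearly apart from isobutyl, with an 8.8-fold lower number from compound 2 to compound 4 (0.95 log units; beyond the scatter) on that swap, and from methyl, with a 19-fold lower number from compound 1 to compound 4 (1.28 log units; beyond the scatter) as the only step in this small set that counts as large, but no measurement here offers a reason for the gain.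

The compounds shown leave open whether the gain belongs to the oxygen itself or simply to a group reaching further out, a question that ethoxy, hydroxy, ethyl or a halogen such as fluorine or chlorine on the same aromatic carbon could help to settle. They also leave open whether methoxy would do the same on the isobutyl chain's replacement by other aromatic groups, such as a pyridine ring carrying methoxy.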